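The source may hold more compounds than are shown below. What is called first, only, known or untested is meant among the compounds shown, and "the series" means these compounds.

Compound 1, `Oc1ccc(-c2cc(-c3cccc(F)c3)cc(-c3ccccc3O)n2)cc1`: in a functional assay on HCT-15 cells (Homo sapiens) for inhibition (on this read-out higher numbers stand for weaker inhibition and lower numbers for stronger inhibition), compound 1 gives > 50000 nM, which is a limit of the assay and not a number.
Compound 2, `Oc1ccc(-c2cc(-c3cccc(F)c3)cc(-c3ccc(O)cc3)n2)cc1`: in this assay compound 2 gives > 50000 nM, again a limit of the assay.

For the measured compounds named here, compound 1 therefore stands only at a limit in this assay; no number is known for it, and the one other value shown is the same limit, namely (the limit of > 50000 nM in this assay, at which 2 of the 2 values shown sit). Going by the values given here, the single measured step, a step that the two limits leave unreadable from compound 1 to compound 2, cannot be given a size, as both of its ends sit at that limit. Compound 3, `Oc1ccc(-c2cc(-c3cccc(C(F)(F)F)c3)cc(-c3ccccc3O)n2)cc1`, differs from compound 1 by trifluoromethyl in place of fluoro on an aromatic carbon. Among the compounds with values here, no measured step touches a trifluoromethyl group, so the only guide is that compound 1 and compound 2 both stop at the limit. The step expected for compound 3, a step that the limit leaves unreadable from compound 1 to compound 3, is small, and compound 3 is expected most likely to remain at the limit. Compound 3 is estimated at 60000 nM, within the range 10000 nM to 300000 nM.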

Compound 3, half-maximal inhibitory concentration: > 50000 nM
Compound 3 was reported as a limit (the forecaster's own chance of this, stated with the estimate: 80%); the middle value is on the limit's open side.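

The step from compound 1 to compound 3, trifluoromethyl in place of fluoro, cannot be read, as both compounds stop at a limit of the assay and not at a number: the limit of > 50000 nM in this assay, at which 3 of the 3 values shown sit. The compounds shown leave open whether any change to the shared core gives a measurable value in this assay.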